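Bromo to trifluoromethyl on the thiourea aryl: series notes

A few compounds are considered here, and "the series" means these few. Any claim that something is new, unique, unknown or untested is made for them only; others in the source may bear on it.

Compound 1 `NC(=O)c1c(NC(=O)c2ccccc2Br)sc2c1CCN(C(=S)Nc1ccccc1Br)C2` carries bromo on both aryl rings. In a functional assay on HeLa cells (Homo sapiens) for antiproliferative activity, with a stated time of 24 h (a lower number here means a stronger inhibitor, a higher number a weaker inhibitor), compound 1 gives 24700 nM. Compound 2 `NC(=O)c1c(NC(=O)c2ccccc2Br)sc2c1CCN(C(=S)Nc1ccccc1C(F)(F)F)C2` differs from it by trifluoromethyl in place of bromo on an aromatic carbon and in this assay compound 2 gives 39600 nM. That change made a step of a 1.6-fold higher number from compound 1 to compound 2 (0.20 log units; within the scatter), so the two values do not separate.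

Compound 3 `NC(=O)c1c(NC(=O)c2ccccc2I)sc2c1CCN(C(=S)Nc1ccccc1Br)C2` differs from compound 1 by iodo in place of bromo on an aromatic carbon. For compound 3 in this assay only a limit is reported, > 50000 nM. For the measured compounds named here, the step is an at least 2.0-fold higher number from compound 1 to compound 3 (0.30 log units; that floor lies within the scatter), and compound 3 is the one value sitting at the limit of > 50000 nM in this assay, at which 1 of the 3 values shown sits.

Compound 4 `NC(=O)c1c(NC(=O)c2ccccc2I)sc2c1CCN(C(=S)Nc1ccccc1C(F)(F)F)C2` is not yet measured. It differs from compound 3 by trifluoromethyl in place of bromo on an aromatic carbon. Going by the values given here, this is the same change as the one from compound 1 to compound 2, at a place described in the same words in both pairs; the cores of the two pairs differ by the change already told for compound 3 against compound 1.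

For compound 4 in this assay the expected step is a step that the limit leaves unreadable from compound 3 to compound 4, resting on the small step of a 1.6-fold higher number from compound 1 to compound 2 (0.20 log units; within the scatter) seen for the same change on the other core. Since compound 3 already sits at the limit, compound 4 is expected to give only a limit as well, with an estimate of 80000 nM and a range of 40000 nM to 200000 nM.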

Compound 4, half-maximal inhibitory concentration: 49200 nM
For compound 4 the middle estimate is 1.6-fold (0.21 log units) above the measured one, and the stated range covers the measured number.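

Compound 3 is reported only as a limit in this assay, > 50000 nM. The step for trifluoromethyl in place of bromo on its core, an at least 1.0-fold lower number from compound 3 to compound 4 (0.00 log units; that floor lies within the scatter), cannot be read as a size, and the values show neither that this change carries over between the two cores nor that it fails to: the same change on two cores in this assay, a 1.6-fold higher number (0.20 log units; within the scatter) from compound 1 to compound 2 and an at least 1.0-fold lower number (0.00 log units; that floor lies within the scatter) from compound 3 to compound 4; the limit leaves it open whether they differ. For the compounds shown here, the one new step with two real numbers is for iodo in place of bromo on the trifluoromethyl side, a 1.2-fold higher number from compound 2 to compound 4 (0.09 log units; within the scatter), so in this assay that swap does not separate compound 2 from compound 4. Its counterpart on the bromo side rests on the same limit, so this change too cannot be said to carry over or not: the same change on two cores in this assay, an at least 2.0-fold higher number (0.30 log units; that floor lies within the scatter) from compound 1 to compound 3 and a 1.2-fold higher number (0.09 log units; within the scatter) from compound 2 to compound 4; the limit leaves it open whether they differ.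

A real test of transfer would need a pair of cores on which all four values are numbers rather than limits, and the compounds shown give no such set. Also open, from the compounds shown here alone, is how either aryl position behaves with a group other than a halogen or trifluoromethyl, such as an amine or a carboxylic acid.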